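Chloro in place of methoxy: cytotoxicity notes

The compounds below may be only part of what the source reports. "The series", "measured", "known", "first", "only" and "open" are said of these compounds alone.

Of the compounds shown here, three have been measured in a functional assay on HFF cells (Homo sapiens) for cytotoxicity (on this read-out lower numbers stand for stronger inhibition and higher numbers for weaker inhibition), and a fourth is pending. Compound 1 (`CCCCOC[C@H]1O[C@@H](n2c(Cl)nc3cc(Cl)c(Cl)cc32)[C@H](OC(C)=O)[C@@H]1OC(C)=O`) gives 66000 nM. Compound 2 (`CC(=O)OC1C(CF)OC(n2c(Cl)nc3cc(Cl)c(Cl)cc32)C1OC(C)=O`) gives 32000 nM. Compound 3 (`COC[C@H]1OC(n2c(Cl)nc3cc(Cl)c(Cl)cc32)[C@H](O)[C@@H]1O`) gives 32000 nM, level with compound 2 and, together with it, the lowest of the three numbers. Compound 1 stands higher, just beyond the scatter.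

The next compound is compound 4 (`O[C@@H]1[C@@H](CCl)OC(n2c(Cl)nc3cc(Cl)c(Cl)cc32)[C@@H]1O`), which carries chloro in place of the methoxy of compound 3, on a saturated chain carbon bound to a saturated ring carbon: chloro in place of methoxy on a saturated chain carbon bound to a saturated ring carbon. Cut one bond further out, the same difference reads methoxymethyl to chloromethyl.

Among the compounds with values here, no two measured compounds differ in one place, so the series offers no direct precedent for this change. Within the data shown here, the only guide is the narrow spread of the measured values, from compound 3 at 32000 nM to compound 1 at 66000 nM. In this assay, no step beyond the scatter is expected in either direction, and the expected 1.1-fold lower number from compound 3 to compound 4 (0.03 log units; within the scatter) is small. With so little precedent, the range is kept wide. For compound 4 the estimate is 30000 nM, with an expected range from 12000 nM to 80000 nM.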

Compound 4, half-maximal inhibitory concentration: 32000 nM
For compound 4 the middle estimate is 1.1-fold (0.03 log units) below the measured one; the measured number falls inside the stated range.
By their numbers in this assay, from the lowest: compounds 2, 3 and 4 (each within the scatter of the next); then compound 1.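

Within the data shown here, compound 3 and compound 4 form the first pair that differs in one place, and in this assay chloro in place of methoxy on a saturated chain carbon bound to a saturated ring carbon gives no change at the digits printed from compound 3 to compound 4 (within the scatter). At this position, methoxymethyl and chloromethyl therefore read alike on this cytotoxicity measure, although the change removes one hydrogen-bond acceptor and one heavy atom; this holds for this single pair only. Nothing available explains why the two groups read alike, so the result stands as an observation without a known cause.

Among these compounds, whether an amine, a carboxylic acid or a longer chain on the same chain carbon would stay level with compound 3 remains open, as the pair samples only two small groups and neither reaches the far side of the range of numbers seen so far. Among the compounds shown here, also open is whether the same exchange would read alike on a core carrying the two acetate esters of compound 1 and compound 2, since the one step available rests on the core of compound 3.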